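The compounds below may be only part of what the source reports. "The series", "measured", "known", "first", "only" and "open" are said of these compounds alone.

Measured in an assay on isolated protein with Bile acid receptor (Homo sapiens) as the target; on this read-out higher numbers stand for an effect only at larger amounts of compound and lower numbers for an effect already at smaller amounts:
compound 1 `COC(=O)/C=C/c1cccc(N(Cc2ccc(/C=C/c3c(Cl)cccc3Cl)cc2)C(=O)C(C)C)c1`, 195 nM;
compound 2 `COC(=O)/C=C/c1cccc(N(Cc2ccc(-c3ccc(OC)cc3)cc2)C(=O)C(C)C)c1`, 97 nM;
compound 3 `COC(=O)/C=C/c1cccc(N(Cc2ccc(-c3ccc(C)cc3)cc2)C(=O)C(C)C)c1`, 118 nM.

Compound 3 stands second highest of these three numbers, with a 1.2-fold higher number from compound 2 to compound 3 (0.09 log units; within the scatter) and a 1.7-fold lower number from compound 1 to compound 3 (0.22 log units; within the scatter), so all three compounds sit within the scatter of one another. Compound 4 `COC(=O)/C=C/c1cccc(N(Cc2ccc(-c3cccc(C)c3)cc2)C(=O)C(C)C)c1` differs from compound 3 by 3-methylphenyl in place of 4-methylphenyl on an aromatic carbon. Among the measured compounds shown here, no measured step moves a substituent around the same ring in this way; the three measured steps, a 2.0-fold lower number from compound 1 to compound 2 (0.30 log units; within the scatter), a 1.7-fold lower number from compound 1 to compound 3 (0.22 log units; within the scatter) and a 1.2-fold higher number from compound 2 to compound 3 (0.09 log units; within the scatter), all exchange the whole terminal group and all stay within the scatter. This series therefore gives no reason to expect a step beyond the scatter in this assay, and the estimated step is a 1.1-fold higher number from compound 3 to compound 4 (0.04 log units; within the scatter). Compound 4 is estimated at 130 nM, with a range of 60 nM to 280 nM.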

Compound 4, half-maximal effective concentration: 163 nM
Estimate against measurement, compound 4: 1.3-fold (0.10 log units) below; low and high end bracket the measured number.
By their numbers in this assay, from the lowest: compounds 2, 3, 4 and 1 (each within the scatter of the next).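

Unlike the earlier steps, which exchange the whole terminal group, this change only moves the methyl around the ring, from 4-methylphenyl to 3-methylphenyl, and in this assay it gives a 1.4-fold higher number from compound 3 to compound 4 (0.14 log units; within the scatter). The comparisons with the other terminal groups, a 1.7-fold higher number from compound 2 to compound 4 (0.23 log units; within the scatter) and a 1.2-fold lower number from compound 1 to compound 4 (0.08 log units; within the scatter), also stay within the scatter, so the methyl's place on this ring separates none of these compounds. No evidence here bears on these steps.

Going by these compounds, whether a carboxylic acid or an amine on this ring would give a step beyond the scatter remains open.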